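Series notes: metabolic stability across three amine chains

The source may report more compounds than this note shows. Statements on the series, on what has been measured and on what is new or still open speak of the compounds shown alone.

Compound 1 `CN(C[C@@H]1Cc2ncccc2CN1)[C@H]1CCCc2cccnc21` sets the reference point for the series. In an ADME assay on microsomes from liver (Homo sapiens) for metabolic stability, using NADPH, with a stated time of 10 min (a higher number here means that more of the compound is left, a lower number that less of the compound is left), compound 1 gives 100%. Compound 2 `NC(=O)NC/C=C\CN(C[C@H]1Cc2ncccc2CN1)[C@H]1CCCc2cccnc21` is level with compound 1: in this assay compound 2 gives 100%, a reading that sits with compound 1 within the scatter of the method. No step between measured compounds can be drawn from this pair, since the two readings do not differ at the digits shown.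

Compound 3 `c1cnc2c(c1)CN[C@@H](CN(CCCC1CCNCC1)[C@H]1CCCc3cccnc31)C2` has not been measured. It differs from compound 2 in one place: a group of 8 heavy atoms (7 carbon, 1 nitrogen; one six-membered non-aromatic ring with 1 hetero atom) in place of a group of 7 heavy atoms (4 carbon, 2 nitrogen, 1 oxygen; no ring), on a saturated chain carbon bound to an amine nitrogen. For the measured compounds named here, the two measured compounds carry different groups at that position and both read as fully remaining, so there is no measured step to lean on, and nothing is known about how the group with the six-membered non-aromatic ring behaves in this assay. On that basis the step of a number 12 percentage points lower from compound 2 to compound 3 (beyond the scatter) is expected to be small and, if anything, downward, most likely not beyond the scatter. Compound 3 is estimated at 88%, with a range from 65% to 100%.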

Compound 3, percent of the compound remaining: 100%
For compound 3 the middle estimate is 12 percentage points below the measured one; low and high end bracket the measured number.
By their numbers in this assay, from the lowest: compounds 1, 2 and 3 (each within the scatter of the next).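

On a saturated chain carbon bound to an amine nitrogen, the ring-free group of compound 2 gives way to 2-(piperidin-4-yl)ethyl with no change at the digits printed from compound 2 to compound 3 (within the scatter) in this assay. For the compounds shown here, this is the only measured step at this position, and it shows that a chain carrying one six-membered non-aromatic ring with 1 hetero atom gives the same printed reading as the ring-free group, which has 2 hydrogen-bond donors and 2 double bonds outside aromatic rings, with compound 3 at 100%. No supporting data are available to account for this result.

On these data alone, compound 2 and compound 3 print the same number, so this pair gives no means of ranking the two groups, and it remains open whether any group at this position would bring the reading in this assay down beyond the scatter. Also open, as far as these compounds go, is how a carboxylic acid at the end of the chain, a morpholine ring in place of the piperidine, or a longer chain bearing the same piperidine would read in this assay.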